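The source may report more compounds than this note shows. Statements on the series, on what has been measured and on what is new or still open speak of the compounds shown alone.

In a physicochemical assay for solubility, measured as kinetic solubility (on this read-out higher numbers stand for higher solubility and lower numbers for lower solubility), compound 3 (`CCC/N=C1\S/C(=C\c2ccc(O)c(Cl)c2)C(=O)N1C1CCOCC1`) gives 70000 nM. That places it within the usual scatter of compound 1 (`CCC/N=C1\S/C(=C\c2ccc(O)cn2)C(=O)N1c1ccccc1C`), which gives 110000 nM. Compound 2 (`CCC/N=C1\S/C(=C\c2ccc(O)c(C(F)(F)F)c2)C(=O)N1c1ccccc1C`), at 14000 nM, lies lower than compound 3 by more than the scatter.

Compound 4 (`CCC/N=C1\S/C(=C\c2ccc(O)c(Cl)c2)C(=O)N1C(C)C`) has not yet been measured. It differs from compound 3 in one place: isopropyl in place of oxan-4-yl on an amide-type nitrogen in a ring, with isopropyl in place of oxan-4-yl on an amide-type nitrogen in a ring. Among the compounds with values here, no two measured compounds differ in only one place, so the data offer no direct guide to this change, and the expectation rests on the structural change alone. A small step downward in this assay is expected, one that stays within the scatter, though the uncertainty in its size and direction is wide. The estimated step is a 1.8-fold lower number from compound 3 to compound 4 (0.24 log units; within the scatter). For compound 4 the expected value is 40000 nM, with an estimated range of 12000 nM to 100000 nM.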

Compound 4, solubility: 20000 nM
Beside the measured number, compound 4's estimate is 2.0-fold (0.30 log units) above it; low and high end bracket the measured number.
By their numbers in this assay, from the lowest: compounds 2 and 4 (each within the scatter of the next); then compounds 3 and 1 (each within the scatter of the next).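

Within the data shown here, at the amide-type nitrogen in the ring, compound 3 and compound 4 give the first direct reading of a single change in this assay: isopropyl in place of oxan-4-yl brings a 3.5-fold lower number from compound 3 to compound 4 (0.54 log units; beyond the scatter). This shows that, with the rest of the structure held the same, the group at this position can move the read-out beyond the scatter, here as the six-membered non-aromatic ring and its oxygen leave. No evidence is given that bears on why the number moves.

Going by these compounds, this remains a single pair, so it is open whether the step would recur with the other groups seen on the shared core. On these data alone, it is also open where a longer chain, a cyclohexyl ring or a piperidin-4-yl ring carrying an amine nitrogen would fall at this position.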